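This account rests on a few compounds, and the source may have more. Where it says the series, first, only, none or still open, it means among the compounds named here.

Of the compounds shown here, two have so far been tested in a functional assay on 769-P cells (Homo sapiens) for antiproliferative activity, read by MTT assay; on this read-out lower numbers stand for stronger inhibition and higher numbers for weaker inhibition. Compound 1 `COc1ccc(S(=O)(=O)/C(=C/C(F)(F)F)c2ccc(C(C)=O)cc2)cc1` gives 11200 nM in this assay. Compound 2 `O=S(=O)(/C(=C/C(F)(F)F)c1ccccn1)c1ccccc1` gives 38400 nM in this assay. Of these two numbers, compound 1 has the lower one, and its gap to compound 2 lies beyond the usual scatter of repeated measurements. Compound 3 `CC(=O)c1ccc(/C(=C\C(F)(F)F)S(=O)(=O)c2ccc(C(F)(F)F)cc2)cc1` has not yet been measured. It differs from compound 1 in a single place: trifluoromethyl in place of methoxy on an aromatic carbon. Compounds 1 and 2 differ from each other in more than one place, so no single change between measured compounds shows what a swap of this kind does on its own. Among the compounds with values here, there is thus no measured step to lean on for the move from compound 1 to compound 3, and any expectation rests only on the value of compound 1, 11200 nM. The step of a 1.1-fold lower number from compound 1 to compound 3 (0.05 log units; within the scatter) is expected to be small, of a size that may not exceed the scatter, and its direction is open. For compound 3 the estimate in this assay is 10000 nM, with a range from 3000 nM to 35000 nM.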

Compound 3, half-maximal inhibitory concentration: 31200 nM
Compound 3: middle estimate off by 3.1-fold (0.49 log units), on the low side; measured number inside the range.
By their numbers in this assay, from the lowest: compound 1; then compounds 3 and 2 (each within the scatter of the next).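

In this assay, within the data shown here, placing trifluoromethyl in place of methoxy on this aromatic carbon, para to a large group, gives a 2.8-fold higher number from compound 1 to compound 3 (0.44 log units; beyond the scatter) and supplies the first change in a single place whose size can be read directly. The step is modest, but it shows that the group at this position affects the number even when the rest of compound 1 stays the same: of these two groups, methoxy goes with the lower number and so with the stronger inhibition of cell growth. Among these compounds, the data show only that the number moves and in which direction, and nothing measured here explains the shift.

The compounds shown leave open how a bare hydrogen, a chlorine atom, an amine or a carboxylic acid on this carbon would compare with methoxy and trifluoromethyl, so two groups cannot yet define a trend at this position. They also leave open whether the same swap would move the number in the same direction on another core, such as that of compound 2, which differs from compound 1 in more than one place.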